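The compounds below may be only part of what the source reports. "The series", "measured", "known", "first", "only" and "open" are said of these compounds alone.

Two ribose-bearing purine analogues are compared here, each carrying a substituted benzyl group on the same nitrogen of the shared core. Compound 1 `OC[C@H]1O[C@@H](n2cnc3c(NCc4ccc(F)cc4)ncnc32)[C@H](O)[C@@H]1O` has, in a functional assay on B16 cells (Mus musculus) for antiproliferative activity, with a stated time of 72 h (on this read-out lower numbers stand for stronger inhibition and higher numbers for weaker inhibition), only the entry "not determined" (no result reported), so no number stands for it. Compound 2 `OC[C@H]1O[C@@H](n2cnc3c(NCc4cccc(Br)c4)ncnc32)[C@H](O)[C@@H]1O` gives in this assay a result of > 166000 nM, which is a limit of the assay rather than a measured number. Where compound 2 stands is therefore described only by the limit of > 166000 nM in this assay, at which 1 of the 2 values shown sits, and no finished step between two measured compounds exists in this set.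

Compound 3 `OC[C@H]1O[C@@H](n2cnc3c(NCc4ccc(F)cc4Cl)ncnc32)[C@H](O)[C@@H]1O` differs from compound 2 by 2-chloro-4-fluorophenyl in place of 3-bromophenyl on a saturated chain carbon bound to a nitrogen on an aromatic ring. With compound 2 sitting at the limit, the expected step from compound 2 to compound 3 is none beyond the scatter, a number no higher from compound 2 to compound 3 (the limit leaves the size open). Compound 3 is accordingly estimated at 166000 nM in this assay, within a range from 40000 nM to 500000 nM, with a strong chance that again only a limit is reported.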

Compound 3, half-maximal inhibitory concentration: > 166000 nM
Compound 3: a limit, no number (the forecaster's own chance of this, stated with the estimate: 75%); the middle value sits exactly at the limit.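

Within the data shown here, compound 3, like compound 2, gives only a limit of the assay and no number, so no step between compound 2 and compound 3 can be read. The compounds shown leave open whether any substituted benzyl group on the shared core gives a measured number in this assay.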